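This account rests on a few compounds, and the source may have more. Where it says the series, first, only, none or still open, it means among the compounds named here.

Among the measured compounds shown here, in a functional assay on CHO cells with adenosine receptor A1 (Homo sapiens) as the target, read by cAMP accumulation and immunoassay, with a stated time of 6 min, tested at 1 uM (a higher number here means a weaker effect of the compound at the concentration tested, a lower number a stronger effect), compound 2 `Nc1scc(CN2CCN(c3ccc(Cl)c(C(F)(F)F)c3)CC2)c1C(=O)c1ccc(Cl)cc1` gives -47%, the lowest of the two numbers measured so far; compound 1 `Nc1scc(CN2CCN(c3ccc([N+](=O)[O-])cc3)CC2)c1C(=O)c1ccc(Cl)cc1` gives -8.3%. Compound 3 `Nc1scc(CN2CCN(c3ccc(F)c(F)c3)CC2)c1C(=O)c1ccc(Cl)cc1` differs from compound 2 in one place: 3,4-difluorophenyl in place of 4-chloro-3-(trifluoromethyl)phenyl on an amine nitrogen in a ring. For the measured compounds named here, only one measured step touches the same position, a number 38.7 percentage points lower from compound 1 to compound 2 (beyond the scatter), and it swapped a different pair of groups, so it shows that this position moves the read-out strongly without fixing the direction for compound 3. The step for compound 3 is expected to be a number 22 percentage points higher from compound 2 to compound 3 (beyond the scatter). Compound 3 is therefore estimated at -25%, with a range from -55% to 5%.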

Compound 3, a percentage reported as activity, at one concentration (the size of the read-out at that concentration, not a potency): -78%
Beside the measured number, compound 3's estimate is 53 percentage points above it; measured number outside the range, below it.
By their numbers in this assay, from the lowest: compound 3; then compound 2; then compound 1.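

On this amine nitrogen, 3,4-difluorophenyl gave a number 31 percentage points lower from compound 2 to compound 3 (beyond the scatter) and a number 69.7 percentage points lower from compound 1 to compound 3 (beyond the scatter) in this assay and so holds the lowest number of the three compounds. The smaller group thus carried the read-out further down than 4-chloro-3-(trifluoromethyl)phenyl, showing that the larger group is not needed for a low number here. Nothing available explains this shift. Still open, on these data alone, is how a plain phenyl or a 4-fluorophenyl would read at this position. Also open, as far as these compounds go, is whether a pyridine ring would keep the low number.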